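A Dimethylphenyl Swap on the Aromatic Nitrogen

The source may hold more compounds than are shown below. What is called first, only, known or untested is meant among the compounds shown, and "the series" means these compounds.

Three compounds built on a shared core were tested in an ADME assay on L02 cells (Homo sapiens) for antiproliferative activity, read by MTT assay, with a stated time of 48 h; on this read-out higher numbers stand for weaker inhibition and lower numbers for stronger inhibition. Compound 1 `N#CC1=C(N)Oc2c(c3nc4ccccc4nc3c3ccccc23)C12C(=O)N(Cc1cnnn1-c1ccc(S(N)(=O)=O)cc1)c1ccccc12` gave only a limit of the assay, > 50000 nM. Compound 2 `Cc1ccc(-n2nncc2CN2C(=O)C3(C(C#N)=C(N)Oc4c3c3nc5ccccc5nc3c3ccccc43)c3ccccc32)c(C)c1` likewise reached only a limit, > 50000 nM. The step that the two limits leave unreadable from compound 1 to compound 2 cannot be read. Going by the values given here, compound 3 `N#CC1=C(N)Oc2c(N)cc3nc4ccccc4nc3c2C12C(=O)N(Cc1cnnn1-c1cccc(C(F)(F)F)c1)c1ccccc12` gives the only number in the set, 38100 nM, which is weak inhibition. Compound 4 `Cc1ccc(C)c(-n2nncc2CN2C(=O)C3(C(C#N)=C(N)Oc4c(N)cc5nc6ccccc6nc5c43)c3ccccc32)c1` differs from compound 3 by 2,5-dimethylphenyl in place of 3-(trifluoromethyl)phenyl on an aromatic nitrogen. Among the compounds with values here, no measured step swaps these two groups, and the one measured step that changes the group on this aromatic nitrogen is unreadable, so no change beyond the scatter is expected in this assay. Compound 4 is therefore expected to give 45000 nM, between 20000 nM and 100000 nM. The expected step of a 1.2-fold higher number from compound 3 to compound 4 (0.07 log units; within the scatter) is estimated to lie within the scatter, and a limit rather than a number is possible.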

Compound 4, half-maximal inhibitory concentration: > 50000 nM
Compound 4: no number, only a limit; the forecaster's own chance of this, stated with the estimate: 45%; middle value at least 1.1-fold (0.04 log units) away from the limit.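

Putting 2,5-dimethylphenyl in place of 3-(trifluoromethyl)phenyl on the aromatic nitrogen gives an at least 1.3-fold higher number from compound 3 to compound 4 (0.11 log units; that floor lies within the scatter). Going by these compounds alone, this is the first change at this position whose size has even a floor, although compound 4 gives only a limit, so the full size of the step stays unknown. Compound 4 now joins compound 1 and compound 2 at the same edge of the assay: the limit of > 50000 nM in this assay, at which 3 of the 4 values shown sit.

On these data alone, whether a carboxylic acid or an amine on this phenyl ring would give a readable number stays open. So does the outcome of a longer chain in place of the ring.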